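Swapping a lactam for a fused lactam on the shared core

A few compounds are considered here, and "the series" means these few. Any claim that something is new, unique, unknown or untested is made for them only; others in the source may bear on it.

Compound 2 `CC1(C)CC(=O)N(c2cnn3c2CN(C(=O)Nc2cc(F)c(F)c(F)c2)C(C2CC2)C3)C1` holds the highest of the two numbers measured in a toxicity assay on HepG2 2.2.15 cells (Homo sapiens) for cytotoxicity, read by CellTiter-Glo; a lower number here means that less compound is tolerated, a higher number that more compound is tolerated: compound 2 gives 115000 nM. Its nearest neighbour is compound 1 `O=C(Nc1cc(F)c(F)c(F)c1)N1Cc2c(-c3ccc(F)cc3F)cnn2CC1C1CC1`, which in this assay gives 32100 nM, so that a 3.6-fold higher number from compound 1 to compound 2 (0.55 log units; beyond the scatter). Compound 3 `O=C1c2ccccc2CN1c1cnn2c1CN(C(=O)Nc1cc(F)c(F)c(F)c1)C(C1CC1)C2` has not yet been measured; it differs from compound 2 in one place: a group of 10 heavy atoms (8 carbon, 1 nitrogen, 1 oxygen; one five-membered non-aromatic ring with 1 hetero atom, one six-membered aromatic ring of carbon only) in place of a group of 8 heavy atoms (6 carbon, 1 nitrogen, 1 oxygen; one five-membered non-aromatic ring with 1 hetero atom), on an aromatic carbon. For the measured compounds named here, the only step that bears on this change is a 3.6-fold higher number from compound 1 to compound 2 (0.55 log units; beyond the scatter), where a group without any ring gave way to a five-membered non-aromatic ring with one hetero atom and the number rose. Compound 3 keeps that non-aromatic ring but adds a six-membered aromatic ring of carbon only, so a modest drop toward compound 1 is expected rather than a further rise. Compound 3 is therefore estimated at 70000 nM, within a range from 30000 nM to 150000 nM. The expected step is a 1.6-fold lower number from compound 2 to compound 3 (0.22 log units; within the scatter).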

Compound 3, half-maximal cytotoxic concentration: 38500 nM
The estimate for compound 3 lay 1.8-fold (0.26 log units) above the measured number; the range from low to high includes it.
By their numbers in this assay, from the lowest: compounds 1 and 3 (each within the scatter of the next); then compound 2.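

On this aromatic carbon, keeping the five-membered non-aromatic ring does not by itself hold the number of compound 2 in this assay: the entering group, which also carries a six-membered aromatic ring of carbon only, gives a clear change (a 3.0-fold lower number from compound 2 to compound 3 (0.48 log units; beyond the scatter)). Set against the 2,4-difluorophenyl group, the same group gives a step that stays within the scatter (a 1.2-fold higher number from compound 1 to compound 3 (0.08 log units; within the scatter)), so among these three groups only 4,4-dimethyl-2-oxopyrrolidin-1-yl stands apart. Nothing available on these compounds explains this difference.

The compounds shown leave open whether the two methyl groups of 4,4-dimethyl-2-oxopyrrolidin-1-yl play any part in its higher number. They also leave open what a morpholine ring or an open-chain amide on this aromatic carbon would give.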